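The compounds below may be only part of what the source reports. "The series", "measured", "known", "first", "only" and "open" are said of these compounds alone.

Measured compounds:

Compound 1 `CNC(=O)/C=C1/COc2cc(OS(=O)(=O)c3ccccc3)ccc21` — 34 nM
Compound 2 `CNC(=O)/C=C1/COc2cc(OS(=O)(=O)c3ccc(OC)cc3)ccc21` — 11 nM

Both compounds were tested in an assay (strain Sprague-Dawley) for inhibition of Amine oxidase [flavin-containing] A (Rattus norvegicus), read by spectrophotometry, with a stated time of 5 min; a lower number here means a stronger inhibitor, a higher number a weaker inhibitor. Compound 1 gives 34 nM; compound 2 gives 11 nM. The only step measured so far, a 3.1-fold lower number from compound 1 to compound 2 (0.49 log units; beyond the scatter), leaves compound 2 with the lowest number of the two shown, its nearest neighbour being compound 1.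

Compound 3 `CNC(=O)/C=C1/COc2cc(OS(=O)(=O)CCC(F)(F)F)ccc21` has not yet been measured. The change from compound 2 to compound 3 is 3,3,3-trifluoropropyl in place of 4-methoxyphenyl on a sulfonyl sulfur. For the measured compounds named here, the one measured step bears on it only in part: it shows that the group on the sulfonyl sulfur does move the result in this assay, and that the methoxy accounts for the gain seen from compound 1 to compound 2. Going by the values given here, compound 3 keeps neither the methoxy nor the ring, so that gain is not expected to carry over, and the bare step from aryl to chain has no measured counterpart here. The expectation for compound 3 in this assay is therefore a weaker result, with a 3.6-fold higher number from compound 2 to compound 3 (0.56 log units; beyond the scatter).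

Compound 3 is estimated at 40 nM, in a range from 12 nM to 150 nM.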

Compound 3, half-maximal inhibitory concentration: 9.1 nM
The estimate for compound 3 lay 4.4-fold (0.64 log units) above the measured number; the whole stated range lies above it.
By their numbers in this assay, from the lowest: compounds 3 and 2 (each within the scatter of the next); then compound 1.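

In this assay, an aromatic ring on the sulfonyl sulfur proves not to be needed: with a 1.2-fold lower number from compound 2 to compound 3 (0.08 log units; within the scatter), the 3,3,3-trifluoropropyl chain and the 4-methoxyphenyl group cannot be told apart, although the chain has no ring and no hydrogen-bond acceptor. Measured against the plain phenyl group, the same chain gives a 3.7-fold lower number from compound 1 to compound 3 (0.57 log units; beyond the scatter), so at this position a result beyond the scatter of the phenyl compound is no longer tied to a methoxy on an aromatic ring. Nothing available explains why two such different groups give results within the scatter of each other.

The compounds shown leave open whether the fluorine atoms contribute at all, which a plain propyl group on the sulfonyl sulfur would test, and whether a shorter chain such as methyl or a longer one such as butyl would hold the same level. They also leave open whether a different group on the aromatic ring, such as a chlorine atom or a nitrile, would match the methoxy.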